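Cinnamyl ether in place of hexyl ether on the shared core

This account rests on a few compounds, and the source may have more. Where it says the series, first, only, none or still open, it means among the compounds named here.

Compound 1 `C[C@H]1CO[C@]2(C)Oc3c(c4c(c5c3C[C@@H]3[C@@H](C)CO[C@]3(C)O5)C[C@@H]3[C@@H](C)CO[C@]3(C)O4)C[C@H]12` gives 31000 nM in a functional assay on aorta (Rattus norvegicus, strain Sprague-Dawley) for inhibition; on this read-out higher numbers stand for an effect only at larger amounts of compound and lower numbers for an effect already at smaller amounts. Compound 2 `CCCCCCOc1cc2c(c3c1C[C@@H]1[C@@H](C)CO[C@]1(C)O3)C[C@@H]1[C@@H](C)CO[C@]1(C)O2` is reported in this assay only as a limit, > 200000 nM, so it stands at the limit of > 200000 nM in this assay, at which 1 of the 2 values shown sits, and no number is known for it. Compound 3 `C[C@H]1CO[C@]2(C)Oc3cc(OC/C=C/c4ccccc4)c4c(c3C[C@H]12)O[C@@]1(C)OC[C@H](C)[C@H]1C4` carries the change (2-phenylethenyl in place of pentyl on a saturated chain carbon bound to an oxygen on an aromatic ring); whether this moves the value cannot be read from any measured step. Compound 3 is expected at 150000 nM, between 40000 nM and 400000 nM, with a good chance that only a limit is reported again. The expected step of an at least 1.3-fold lower number from compound 2 to compound 3 (0.12 log units; that floor lies within the scatter) is thus estimated as no more than modest, with no direction secured beyond the scatter.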

Compound 3, half-maximal effective concentration: > 200000 nM
Compound 3: a limit, no number (the forecaster's own chance of this, stated with the estimate: 50%); middle value at least 1.3-fold (0.12 log units) from the limit.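

Within the data shown here, compound 3 is also reported in this assay only as a limit, so no step from compound 2 to compound 3 can be read: the limit of > 200000 nM in this assay, at which 2 of the 3 values shown sit. Going by these compounds, whether 2-phenylethenyl in place of pentyl moves the value at all stays open.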